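The compounds below may be only part of what the source reports. "The series", "measured", "known", "first", "only" and "open" are said of these compounds alone.

Measured so far:
compound 1, `CC(C(=O)O)c1nn(Cc2cn3cc(OCC4CC4)c(C(F)(F)F)cc3n2)c2ccccc2c1=O`: 71.7 mL/min/kg
compound 2, `CC(C)(C(=O)O)c1nn(Cc2cn3cc(OCC4CC4)c(Cl)cc3n2)c2ccccc2c1=O`: 317 mL/min/kg

Both compounds were run in an ADME assay on cells (Hepatocyte, Mus musculus) for metabolic stability, read by LC-MS, with a stated time of 180 min, tested at 1 uM; on this read-out lower numbers stand for slow clearance and higher numbers for fast clearance. Compound 2 gives the higher of the two numbers, and the nearest measured neighbour, compound 1, lies well below it, a gap that is beyond the usual scatter of repeated measurements. Compound 3, `C[C@H](C(=O)O)c1nn(Cc2cn3cc(OCC4CC4)c(Cl)cc3n2)c2ccccc2c1=O`, has not yet been measured. It differs from compound 2 in a single place: 1-carboxyethyl in place of 1-carboxy-1-methylethyl on an aromatic carbon. Going by the values given here, compound 1 differs from compound 2 in more than one place, so no measured pair isolates this particular change, and the two known values only show that the shared core can be cleared either quickly or slowly.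

With that in mind, the expectation for compound 3 leans downward, because compound 1 gives 71.7 mL/min/kg in this assay while carrying 1-carboxyethyl among its differences from compound 2. The expected step of a 2.0-fold lower number from compound 2 to compound 3 (0.30 log units; within the scatter) is a decrease, though one that could still fall inside the scatter. Compound 3 is estimated at 160 mL/min/kg, with a likely range from 60 mL/min/kg to 350 mL/min/kg.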

Compound 3, clearance: 33.3 mL/min/kg
Beside the measured number, compound 3's estimate is 4.8-fold (0.68 log units) above it, outside the stated range (below it).
By their numbers in this assay, from the lowest: compound 3; then compound 1; then compound 2.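

In this assay, putting 1-carboxyethyl in place of 1-carboxy-1-methylethyl on this aromatic carbon, next to the ring nitrogen, gives a 9.5-fold lower number from compound 2 to compound 3 (0.98 log units; beyond the scatter) and so moves the compound clearly toward slow clearance. Going by these compounds alone, this is the first pair in the set that differs in one place only, so the shift can be tied to this swap rather than to several changes at once, and it shows that clearance is highly sensitive to a small edit of this group. The swap leaves the counts of hydrogen-bond donors and acceptors unchanged and adds a defined stereocentre, but no measurement here explains why the number falls.

The compounds shown leave open how the mirror-image form of the 1-carboxyethyl group would behave, since a single stereocentre arrangement appears with the chlorine-bearing core. They also leave open how far this position tolerates other groups, such as a carboxylic acid attached directly to the ring, a longer chain ending in a carboxylic acid, or an amine.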